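Chloro substitution on the benzamide ring of the series

The source may report more compounds than this note shows. Statements on the series, on what has been measured and on what is new or still open speak of the compounds shown alone.

Compound 3 `CCN1CCN(c2cc(C)c3cc(NC(=O)c4cc(Cl)cc(Cl)c4)ccc3n2)CC1` gives the lowest of the three numbers in a functional assay on SK-BR-3 cells (Homo sapiens) for antiproliferative activity, read by MTT assay, with a stated time of 72 h (on this read-out higher numbers stand for weaker inhibition and lower numbers for stronger inhibition), at 2660 nM; this is within the scatter of compound 2 `CCN1CCN(c2cc(C)c3cc(NC(=O)c4ccc(Cl)cc4)ccc3n2)CC1` at 3020 nM. Only compound 1 `CCc1ccc(C(=O)Nc2ccc3nc(N4CCN(CC)CC4)cc(C)c3c2)cc1`, at 9850 nM, is separated from it by more than the scatter. Compound 4 `CCN1CCN(c2cc(C)c3cc(NC(=O)c4ccccc4Cl)ccc3n2)CC1` differs from compound 3 by 2-chlorophenyl in place of 3,5-dichlorophenyl on a carbonyl carbon. Going by the values given here, the steps that bear on this are a 1.1-fold lower number from compound 2 to compound 3 (0.06 log units; within the scatter) and a 3.3-fold lower number from compound 1 to compound 2 (0.51 log units; beyond the scatter): once a chloro is present on the benzamide ring, shifting to a second chloro moves the number little, while only the chloro-for-ethyl exchange gave a modest step. A single chloro is retained in compound 4, so a small step is expected, if anything towards a higher number, about a 1.3-fold higher number from compound 3 to compound 4 (0.12 log units; within the scatter). For compound 4 the expected value in this assay is 3500 nM, with a range of 1500 nM to 9000 nM.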

Compound 4, half-maximal inhibitory concentration: > 50000 nM
Compound 4 gave a limit, no number; the forecaster's own chance of this, stated with the estimate: 5%; at least 14-fold (1.15 log units) between middle value and limit.
By their numbers in this assay, from the lowest: compounds 3 and 2 (each within the scatter of the next); then compound 1. At a limit, above all of these: compound 4.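

In this assay compound 4 gives a limit of the assay, not a number: the limit of > 50000 nM in this assay, at which 1 of the 4 values shown sits.

Where the chloro sits on the phenyl matters, a point the earlier chloro compounds did not reveal: 2-chlorophenyl in place of 4-chlorophenyl, with one chlorine in each, gives an at least 16-fold higher number from compound 2 to compound 4 (1.21 log units; beyond the scatter). The exchange for 3,5-dichlorophenyl gives an at least 18-fold higher number from compound 3 to compound 4 (1.27 log units; beyond the scatter), and even the exchange for 4-ethylphenyl, the weakest group with a number, gives an at least 5.0-fold higher number from compound 1 to compound 4 (0.70 log units; beyond the scatter).

Going by these compounds, whether 2-fluorophenyl or 2-methoxyphenyl would follow 2-chlorophenyl remains open. The values give no reason for the loss.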